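The source may hold more compounds than are shown below. What is called first, only, known or untested is meant among the compounds shown, and "the series" means these compounds.

The study reads its compounds in a functional assay on the whole organism (stomach) with Rattus norvegicus as the target; a higher number here means that more compound is needed for the effect, a lower number that less compound is needed. Compound 1 `C/N=C(/NC#N)NCCCCCn1nc(-c2ccccc2)c(C)cc1=O` returns only a limit in this assay, namely > 100 mg/kg. Compound 3 `CN(C)/C(=N/CCCCn1nc(-c2ccccc2)ccc1=O)NC#N` gives a measured dose in this assay of 30.3 mg/kg. Compound 2 `O=c1ccc(-c2ccccc2)nn1CCCC/N=C(\S)Nc1ccc(F)cc1` likewise returns only a limit in this assay, > 100 mg/kg. Compound 2 thus stands at the bound of what this assay reports rather than at a number, the same bound at which two of the three values sit (the limit of > 100 mg/kg in this assay, at which 2 of the 3 values shown sit). Going by the values given here, no step between measured compounds that differ in a single place is known, so the three values show nothing about how any particular structural change moves the dose for half-maximal effect.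

Compound 4 `O=c1ccc(-c2ccccc2)nn1CCCC/N=C(\S)Nc1cccc(F)c1` differs from compound 2 in one place: 3-fluorophenyl in place of 4-fluorophenyl on an amine nitrogen. Among the compounds with values here, with no measured step of this kind to draw on, the change is expected to shift the dose by no more than the usual scatter, in no preferred direction. The step from compound 2 is expected to read a number no higher from compound 2 to compound 4 (the limit leaves the size open). Compound 4 is therefore expected most likely to return a limit as well in this assay. Should a number emerge, compound 4 is estimated at 100 mg/kg, with a range from 30 mg/kg to 300 mg/kg.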

Compound 4, dose for half-maximal effect: > 100 mg/kg
Compound 4: a limit, no number (the forecaster's own chance of this, stated with the estimate: 70%); the middle value sits exactly at the limit.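

Going by these compounds alone, compound 2 and compound 4 both return only a limit in this assay and no step can therefore be read for 3-fluorophenyl in place of 4-fluorophenyl on an amine nitrogen. The compounds shown leave open whether this change moves the dose for half-maximal effect at all, since both stand at the same bound: the limit of > 100 mg/kg in this assay, at which 3 of the 4 values shown sit.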